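From Compound 2 to Compound 4: an Expected Step

A few compounds are considered here, and "the series" means these few. Any claim that something is new, unique, unknown or untested is made for them only; others in the source may bear on it.

Of the compounds shown here, three sharing one core have been measured in an assay for binding affinity to 5-hydroxytryptamine receptor 1F (Homo sapiens), read by radioligand binding; on this read-out higher numbers stand for weaker inhibition and lower numbers for stronger inhibition. Compound 1 `CN1CCC(c2c[nH]c3ccc(NC(=O)c4cccc(F)c4)nc23)CC1` gives 11 nM. Compound 2 `CCN1CC=C(c2c[nH]c3ccc(NC(=O)c4ccc(F)cc4)nc23)CC1` gives 25 nM, the highest of the three numbers; its gap to compound 1 lies beyond the scatter, while compound 3 `CCN1CC=C(c2c[nH]c3ccc(NC(C)=O)nc23)CC1` gives 21 nM, a number within the scatter of compound 2. For the measured compounds named here, the only single-point step recorded is a 1.2-fold lower number from compound 2 to compound 3 (0.08 log units; within the scatter), which shows that the group on the carbonyl carbon hardly moves this assay.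

Compound 4 `CCN1CCC(c2c[nH]c3ccc(NC(=O)c4ccc(F)cc4)nc23)CC1` has not been measured. It differs from compound 2 as a group of 8 heavy atoms (7 carbon, 1 nitrogen; one six-membered non-aromatic ring with 1 hetero atom) in place of a group of 8 heavy atoms (7 carbon, 1 nitrogen; one six-membered non-aromatic ring with 1 hetero atom), on an aromatic carbon. Going by the values given here, no measured step isolates this change: compound 1 carries the saturated ring but differs from compound 2 in three places at once, so its lower number cannot be assigned to the ring alone. The expected step of a 1.4-fold lower number from compound 2 to compound 4 (0.14 log units; within the scatter) is therefore small, likely within the scatter, leaning toward a lower number. For compound 4 this assay is estimated at 18 nM, between 7 nM and 45 nM.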

Compound 4, inhibition constant: 170 nM
The estimate for compound 4 lay 9.4-fold (0.98 log units) below the measured number, outside the stated range (above it).
By their numbers in this assay, from the lowest: compounds 1, 3 and 2 (each within the scatter of the next, the first and the last beyond it); then compound 4.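

Compound 2 and compound 4 carry the same counts of heavy atoms, hydrogen-bond donors and acceptors and the same lack of net charge in this group; what separates them is the double bond outside aromatic rings, absent from the 1-ethylpiperidin-4-yl group, and in this assay that single change gives a 6.8-fold higher number from compound 2 to compound 4 (0.83 log units; beyond the scatter). The earlier step on the carbonyl carbon, a 1.2-fold lower number from compound 2 to compound 3 (0.08 log units; within the scatter), had shown only a change that hardly moved the number, so this position, on an aromatic carbon of the five-membered aromatic ring, is the first place in these compounds where a single change moves the read-out beyond the scatter, and it moves it toward weaker inhibition. Nothing available gives a measured reason for the size of this step.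

This single pair leaves open whether the double bond counts for as much when a methyl rather than 4-fluorophenyl sits on the carbonyl carbon. It also leaves open whether the gap holds with a methyl group or a longer chain such as propyl in place of the ethyl on the nitrogen of the six-membered ring.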